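Ring-bearing substituent on the amide nitrogen: compound 4

The source may report more compounds than this note shows. Statements on the series, on what has been measured and on what is new or still open speak of the compounds shown alone.

Three compounds of the shared core have been run in a functional assay on the whole organism (PC-3 cells) for inhibition, with Mus musculus as the target, in a xenograft, with a stated time of 24 h, at a dose of 100 mg/kg by the oral route; a lower number here means less inhibition, a higher number more inhibition at the dose given (going by the name of the read-out). Compound 1 `CC(C)(O)c1ccc(-c2cnc3c(n2)N(CCC2CCOCC2)C(=O)CN3)cn1` gives 59%. Compound 2 `COCCN1C(=O)CNc2ncc(-c3ccc(C(C)(C)O)nc3)nc21` gives 91%. Compound 3 `CC(C)(O)c1ccc(-c2cnc3c(n2)N(CC2CCOCC2)C(=O)CN3)cn1` gives 91%, level with compound 2 and together with it the highest of the three; compound 1 is the furthest away. The step of a number 32 percentage points higher from compound 1 to compound 3 (beyond the scatter) was large, the step of a number 32 percentage points higher from compound 1 to compound 2 (beyond the scatter) was equally large, and no change at the digits printed from compound 2 to compound 3 (within the scatter) stayed within the scatter.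

Compound 4 `CO[C@H]1CC[C@H](N2C(=O)CNc3ncc(-c4ccc(C(C)(C)O)nc4)nc32)CC1` is unmeasured. Its change from compound 3 is 4-methoxycyclohexyl in place of (oxan-4-yl)methyl on an amide-type nitrogen in a ring. All three measured steps concern the substituent on that same amide-type nitrogen, and two of them reached the same high level, so shortening the substituent there has not lowered this assay in any measured case. A step of about zero or a little downward is expected, a number 6 percentage points lower from compound 3 to compound 4 (within the scatter), since compound 3 already sits at 91% and little room remains upward. Compound 4 is estimated at 85%, range 65% to 97%.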

Compound 4, a percentage reported as inhibition, in the whole organism at one dose (the size of the read-out at that dose, not a potency): 91%
Beside the measured number, compound 4's estimate is 6 percentage points below it; the measured number falls inside the stated range.
By their numbers in this assay, from the lowest: compound 1; then compounds 2, 3 and 4 (each within the scatter of the next).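

In this assay, the amide-type nitrogen in a ring accepts 4-methoxycyclohexyl, with a six-membered ring of carbon only and 2 defined stereocentres: no change at the digits printed from compound 3 to compound 4 (within the scatter) against (oxan-4-yl)methyl, and no change at the digits printed from compound 2 to compound 4 (within the scatter) against 2-methoxyethyl. The ring oxygen of the oxan-4-yl group is therefore not needed at this position to hold the level, while a number 32 percentage points higher from compound 1 to compound 4 (beyond the scatter) against 2-(oxan-4-yl)ethyl leaves that substituent as the only one of the four apart from the rest. No measurement offered here explains why these three substituents read alike.

Going by these compounds, compounds 2, 3 and 4 are not separated at this single dose, so any difference between them at lower doses remains open. Also open, on these data alone, are the other stereoisomer of the 4-methoxycyclohexyl group and whether an amine or a carboxylic acid in place of its methoxy keeps the level.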